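The source may report more compounds than this note shows. Statements on the series, on what has been measured and on what is new or still open speak of the compounds shown alone.

Compound 1 `COc1ccc(/C=C/c2nc(NCCN(C(C)C)C(C)C)c3cc(Cl)ccc3n2)cc1OC` pairs a 3,4-dimethoxyphenyl group with a diisopropylamino tail. In a functional assay on L02 cells (Homo sapiens) for cytotoxicity, read by MTT assay, with stated times of 48 h and 4 h (a higher number here means a weaker inhibitor, a lower number a stronger inhibitor), compound 1 gives > 100000 nM, which is a limit of the assay rather than a number. Compound 2 `COc1ccc(/C=C/c2nc(NCCN3CCCCC3)c3cc(Cl)ccc3n2)cc1OC` differs from it in one place: piperidin-1-yl in place of diisopropylamino on a saturated chain carbon, two bonds along the chain from a nitrogen on an aromatic ring. In this assay compound 2 gives 13900 nM. The change produced an at least 7.1-fold lower number from compound 1 to compound 2 (0.85 log units; beyond the scatter), and its size is shaped by the limit of > 100000 nM in this assay, at which 2 of the 3 values shown sit.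

Compound 3 `CC(C)N(CCNc1nc(/C=C/c2ccc([N+](=O)[O-])cc2)nc2ccc(Cl)cc12)C(C)C` keeps the tail of compound 1 but carries a different core, the difference being (4-nitrophenyl in place of 3,4-dimethoxyphenyl on a double-bonded chain carbon bound to a double-bonded chain carbon). In this assay compound 3 gives > 100000 nM, which is a limit of the assay rather than a number. Between these two the record shows a step that the two limits leave unreadable from compound 1 to compound 3.

Compound 4 `O=[N+]([O-])c1ccc(/C=C/c2nc(NCCN3CCCCC3)c3cc(Cl)ccc3n2)cc1` has not yet been measured in this assay. It differs from compound 3 by piperidin-1-yl in place of diisopropylamino on a saturated chain carbon, two bonds along the chain from a nitrogen on an aromatic ring. Within the data shown here, this is the same change as the one from compound 1 to compound 2, made at the same place on the chain, and both starting points sit at the limit. Compound 4 is therefore expected to show a step of an at least 5.0-fold lower number from compound 3 to compound 4 (0.69 log units; beyond the scatter) in this assay because an at least 7.1-fold lower number from compound 1 to compound 2 (0.85 log units; beyond the scatter) was seen for the same change. For compound 4 the estimated value in this assay is 20000 nM, with a likely range from 4000 nM to 100000 nM, and a real chance that only a limit is reported.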

Compound 4, half-maximal inhibitory concentration: > 100000 nM
Compound 4: a limit, no number; the forecaster's own chance of this, stated with the estimate: 35%; middle value at least 5.0-fold (0.69 log units) away from the limit.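

In this assay compound 4 gives > 100000 nM, which is a limit of the assay and not a number. Among these compounds, the swap of diisopropylamino for piperidin-1-yl, which gave an at least 7.1-fold lower number from compound 1 to compound 2 (0.85 log units; beyond the scatter) with the 3,4-dimethoxyphenyl group, therefore did not bring a numerical value with the 4-nitrophenyl group; the steps that join two limits cannot be read, and the one readable comparison, with the piperidin-1-yl tail held constant, is an at least 7.1-fold higher number from compound 2 to compound 4 (0.85 log units; beyond the scatter). This does not show that the swap does nothing with the 4-nitrophenyl group, or that its effect there is smaller than with the 3,4-dimethoxyphenyl group, since any change among these compounds can be followed only below the ceiling of the assay: the limit of > 100000 nM in this assay, at which 3 of the 4 values shown sit.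

Still open, on these data alone, is whether another cyclic amine on the chain, such as pyrrolidin-1-yl or morpholin-4-yl, would give a numerical value with either of these two aryl groups. Also open, as far as these compounds go, is whether a 4-methoxyphenyl or an unsubstituted phenyl group, carried with the piperidin-1-yl tail, would read like compound 2 or stay at the limit like compound 4.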